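Swapping the Group on Nitrogen in Compound 1

The source may report more compounds than this note shows. Statements on the series, on what has been measured and on what is new or still open speak of the compounds shown alone.

Compound 1 `COc1cc(C(=O)c2cn(-c3cccc(F)c3)cc2-c2ccccc2[N+](=O)[O-])cc(OC)c1OC` gives 190 nM
Compound 2 `COc1cc(C(=O)c2cn(-c3ccc(C)cc3)cc2-c2ccc(N)cc2)cc(OC)c1OC` gives 6 nM
Compound 3 `COc1cc(C(=O)c2cn(-c3ccc(F)cc3)cc2-c2ccccc2F)cc(OC)c1OC` gives 39 nM

All three numbers come from a functional assay on MCF7 cells (Homo sapiens) for cytotoxicity, read by MTT assay, with a stated time of 96 h; on this read-out lower numbers stand for stronger inhibition and higher numbers for weaker inhibition. Compound 1 has the highest number of the three, and the gaps down to compound 3 and to compound 2 both lie beyond the scatter.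

The next compound is compound 4 `COc1cc(C(=O)c2cn(-c3ccc(N)cc3)cc2-c2ccccc2[N+](=O)[O-])cc(OC)c1OC`, which has 4-aminophenyl in place of 3-fluorophenyl on an aromatic nitrogen, while the 2-nitrophenyl group stays: 4-aminophenyl in place of 3-fluorophenyl on an aromatic nitrogen. For the measured compounds named here, no two measured compounds differ in one place only, so the size of this step cannot be read directly from the data. Going by the values given here, the only guide is compound 2 at 6 nM, which holds a 4-aminophenyl group at another place and differs from compound 1 in more than that group. On this thin basis, a moderate step toward a lower number in this assay is expected, probably beyond the scatter. The expected change is a 2.7-fold lower number from compound 1 to compound 4 (0.43 log units; beyond the scatter). For compound 4 the estimated value is 70 nM, with an expected range from 12 nM to 350 nM.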

Compound 4, half-maximal inhibitory concentration: 53 nM
Beside the measured number, compound 4's estimate is 1.3-fold (0.12 log units) above it; the range from low to high includes it.
By their numbers in this assay, from the lowest: compound 2; then compounds 3 and 4 (each within the scatter of the next); then compound 1.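

In this assay, the group on the aromatic nitrogen can move the number on its own: with the 2-nitrophenyl group held fixed, 4-aminophenyl in place of 3-fluorophenyl gives a 3.6-fold lower number from compound 1 to compound 4 (0.55 log units; beyond the scatter). For the compounds shown here, this is the only step here that isolates a single place, and it is a modest step between two groups with the same heavy-atom count, of which only 4-aminophenyl carries a hydrogen-bond donor and acceptor. No measurement shown accounts for the change.

The compounds shown leave open whether the step follows the amine itself, the loss of fluorine or the placement of the substituent on the ring, a question that 3-aminophenyl or 4-hydroxyphenyl on the same nitrogen could help to separate. They also leave open whether the step would keep its size with a group other than 2-nitrophenyl on the neighbouring ring atom.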